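A few compounds are considered here, and "the series" means these few. Any claim that something is new, unique, unknown or untested is made for them only; others in the source may bear on it.

Compound 1 `COc1cc(C2CCN(C)CC2)ccc1Nc1ncc2ccc(-c3ccccc3OC)n2n1`: 1.4 h
Compound 2 `COc1cc(C2CCN(CC(N)=O)CC2)ccc1Nc1ncc2ccc(-c3ccccc3OC)n2n1`: 3.4 h

These two values come from an in vivo ADME assay on the whole organism (strain Sprague-Dawley) for metabolic stability, with Rattus norvegicus as the target, at a dose of 1 mg/kg by the intravenous route; a higher number here means that the compound lasts longer, a lower number that the compound disappears faster. Compound 3 `COc1cc(C2CCN(CC(N)=O)CC2)ccc1Nc1ncc2c(C)cc(-c3ccccc3N(C)S(C)(=O)=O)n2n1` gives only a limit in this assay, > 2 h. Its standing is therefore known only as the limit of > 2 h in this assay, at which 1 of the 3 values shown sits, not as a number. For the measured compounds named here, the one measured step, a 2.4-fold higher number from compound 1 to compound 2 (0.39 log units; beyond the scatter), concerns a carbamoyl in place of hydrogen on a saturated chain carbon bound to an amine nitrogen in a ring, a position that does not change here. Compound 4 `COc1cc(C2CCN(CC(N)=O)CC2)ccc1Nc1ncc2c(Cl)cc(-c3ccccc3N(C)S(C)(=O)=O)n2n1` differs from compound 3 by chloro in place of methyl on an aromatic carbon. Going by the values given here, no measured step touches this aromatic carbon, so no shift beyond the scatter is expected in this assay. Compound 4 is estimated at 3 h, between 1.5 h and 6 h, which means an expected step that the limit leaves unreadable from compound 3 to compound 4.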

Compound 4, half-life: > 2 h
Compound 4 gave a limit, no number; the forecaster's own chance of this, stated with the estimate: 40%; the middle value lies beyond the limit too.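

In this assay, for the compounds shown here, compound 3 and compound 4 each give only a limit, not a number, so no step between them can be read: the limit of > 2 h in this assay, at which 2 of the 4 values shown sit.

From the compounds shown here alone, whether chloro in place of methyl on this aromatic carbon shifts the half-life at all, and in which direction, stays open.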